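Notes on the carbonate and pivaloyl ester series

The source may hold more compounds than are shown below. What is called first, only, known or untested is meant among the compounds shown, and "the series" means these compounds.

In an ADME assay for metabolic stability, read by LC-MS, with a stated time of 3 h, at pH 6.5, tested at 50 uM (on this read-out higher numbers stand for a more stable compound and lower numbers for a less stable compound), compound 1 `CC(OC(=O)C1=C(S[C@@H]2CN[C@H](C(=O)Nc3cccc(C(=O)OC(C)OC(=O)C(C)(C)C)c3)C2)[C@H](C)[C@@H]2[C@@H]([C@@H](C)O)C(=O)N12)OC(=O)C(C)(C)C` gives > 95%, which is a limit of the assay and not a number. Compound 2 `CC(C)OC(=O)OCOC(=O)C1=C(S[C@@H]2CN[C@H](C(=O)Nc3cccc(C(=O)O)c3)C2)[C@H](C)[C@@H]2[C@@H]([C@@H](C)O)C(=O)N12` gives > 95% in this assay, again a limit. Compound 3 `CC(C)OC(=O)OCOC(=O)C1=C(S[C@@H]2CN[C@H](C(=O)Nc3cccc(C(=O)OCOC(=O)OC(C)C)c3)C2)[C@H](C)[C@@H]2[C@@H]([C@@H](C)O)C(=O)N12` likewise gives > 95% in this assay, a limit. Compound 2 therefore stands at the limit like the other two shown, and no order among them can be read from these values. Within the data shown here, the only step with a measured pair around compound 2 is a step that the two limits leave unreadable from compound 2 to compound 3, so it gives no size.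

Compound 4 `C[C@@H](O)[C@H]1C(=O)N2C(C(=O)OCOC(=O)OC(C)(C)C)=C(S[C@@H]3CN[C@H](C(=O)Nc4cccc(C(=O)O)c4)C3)[C@H](C)[C@H]12` has not been measured in this assay. It differs from compound 2 by methyl in place of hydrogen on a saturated chain carbon bound to an oxygen next to a carbonyl group and two saturated chain carbons. Among the measured compounds shown here, no measured step bears on this change in a readable way; what the series shows is the limit of > 95% in this assay, at which 3 of the 3 values shown sit. With every value shown at the limit, the expected step is a step that the limit leaves unreadable from compound 2 to compound 4, that is none beyond the scatter, and compound 4 is expected to stay at the limit. The estimate for compound 4 in this assay is 96%, with a range from 88% to 100%.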

Compound 4, percent of the compound remaining: > 95%
Compound 4: no number, only a limit; the forecaster's own chance of this, stated with the estimate: 85%; the middle value does not contradict the limit.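

Compound 4 gives > 95% in this assay, which is a limit of the assay and not a number. With compound 2 also at a limit, no step from isopropyl to tert-butyl can be read: the limit of > 95% in this assay, at which 4 of the 4 values shown sit.

The compounds shown leave open whether this change, or any other difference among them, alters the percent remaining.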